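Working notes: aryl for alkyl on the shared five-membered ring

This account rests on a few compounds, and the source may have more. Where it says the series, first, only, none or still open, it means among the compounds named here.

Measured so far in a functional assay on PC-3 cells (Homo sapiens) for cytotoxicity, read by sulforhodamine B assay, tested at 10 uM; a lower number here means less inhibition, a higher number more inhibition at the concentration tested (going by the name of the read-out):
compound 1 `CCCc1cc(-c2cn([C@H]3C[C@H](OC(C)=O)[C@@H](COC(C)=O)O3)c(=O)[nH]c2=O)on1` gives 88.1%
compound 2 `CCCCCc1cc(-c2cn([C@H]3C[C@H](OC(C)=O)[C@@H](COC(C)=O)O3)c(=O)[nH]c2=O)on1` gives 93.9%
compound 3 `CC(=O)OC[C@H]1O[C@@H](n2cc(-c3cn(Cc4ccc(C(C)C)cc4)nn3)c(=O)[nH]c2=O)C[C@@H]1OC(C)=O` gives 91.3%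

Compound 2 has the highest number of the three, but both compound 3 and compound 1 lie within the scatter of it, so no order among them is claimed. The next compound, compound 4 `CC(=O)OC[C@H]1O[C@@H](n2cc(-c3cc(-c4ccc(C(C)(C)C)cc4)no3)c(=O)[nH]c2=O)C[C@@H]1OC(C)=O`, differs from compound 2 by 4-(tert-butyl)phenyl in place of pentyl on an aromatic carbon. Within the data shown here, the only measured step at that position is a number 5.8 percentage points higher from compound 1 to compound 2 (within the scatter), a chain lengthening that stayed within the scatter. Among the measured compounds shown here, no measured step puts an aromatic group at this carbon; compound 3, which carries an aryl group elsewhere, sits at the same level as the alkyl compounds. Compound 4 is therefore expected to give 90% (range 78% to 98%), a step of a number 3.9 percentage points lower from compound 2 to compound 4 (within the scatter), not beyond the scatter.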

Compound 4, a percentage reported as inhibition, at one concentration (the size of the read-out at that concentration, not a potency): 27.5%
Compound 4: the middle estimate sits 62.5 percentage points above what was measured, and the stated range ends above it.
By their numbers in this assay, from the lowest: compound 4; then compounds 1, 3 and 2 (each within the scatter of the next).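

In this assay this position proves sensitive to the group it carries: 4-(tert-butyl)phenyl in place of pentyl gives a number 66.4 percentage points lower from compound 2 to compound 4 (beyond the scatter) and the same group in place of propyl gives a number 60.6 percentage points lower from compound 1 to compound 4 (beyond the scatter). The number is level between the two alkyl chains and lower with this aryl group. Nothing measured here bears on the reason for the drop.

As far as these compounds go, whether the loss belongs to the phenyl ring or to its tert-butyl group stays open. Also open, from the compounds shown here alone, is what an unsubstituted phenyl or a cyclohexyl group would give at this carbon.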